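The source may hold more compounds than are shown below. What is called first, only, known or untested is meant among the compounds shown, and "the series" means these compounds.

Working notes on the series. The shared core is that of compound 1 `C#Cc1cc(-c2nc3ccccc3s2)ccc1N`, which in a functional assay on MDA-MB-468 cells (Homo sapiens) for inhibition, with a stated time of 72 h (a higher number here means a weaker inhibitor of growth, a lower number a stronger inhibitor of growth), gives 15 nM. Of the two numbers recorded in this assay, compound 1 stands highest; its nearest neighbour is compound 2 `C#Cc1cc(-c2nc3cc(F)ccc3s2)ccc1N`, which in this assay gives 6.8 nM, the step being a 2.2-fold lower number from compound 1 to compound 2 (0.34 log units; beyond the scatter). That step introduces a fluoro in place of hydrogen on an aromatic carbon of the core.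

Compound 3 `C[Si](C)(C)C#Cc1cc(-c2nc3ccccc3s2)ccc1N` has not yet been measured in this assay. Compared with compound 1, the change is a group of 4 heavy atoms (3 carbon, 1 silicon; no ring) in place of a hydrogen atom, on a triple-bonded carbon. Within the data shown here, no measured step touches the triple-bonded carbon, so the single step from compound 1 to compound 2 does not bear on this change, and it is the only step recorded. The change is larger in heavy-atom count than the fluoro step, and it enters at a place not yet varied; the expectation is therefore uncertain and wide. For compound 3 the estimated step is a 4.0-fold higher number from compound 1 to compound 3 (0.60 log units; beyond the scatter), towards a higher number. Compound 3 is expected at 60 nM, with a range from 15 nM to 300 nM.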

Compound 3, concentration for 50% growth inhibition: 560 nM
Beside the measured number, compound 3's estimate is 9.3-fold (0.97 log units) below it, outside the stated range (above it).
By their numbers in this assay, from the lowest: compound 2; then compound 1; then compound 3.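

Among these compounds, the triple-bonded carbon, which the earlier compounds left unchanged, proves to be a place where substitution counts heavily in this assay: a group of 4 heavy atoms (3 carbon, 1 silicon; no ring) in place of a hydrogen atom gives a 37-fold higher number from compound 1 to compound 3 (1.57 log units; beyond the scatter), a large step. Among the compounds shown here, the only earlier step, on an aromatic carbon of the core, was modest at a 2.2-fold lower number from compound 1 to compound 2 (0.34 log units; beyond the scatter), so the series now shows that the terminal hydrogen of compound 1 cannot be replaced by this group without a marked rise in the number. No supporting measurement is available to account for the size of this step.

Open, from the compounds shown here alone, is whether the rise follows from the silicon atom or from any group entering on this carbon, and a methyl or a tert-butyl on the same triple-bonded carbon would separate the two readings. Also open, going by these compounds, is whether a more polar entrant, such as a hydroxymethyl or an amine on a short chain, would behave like this group, and whether the fluoro step holds when this group is present.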